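Amide aryl exchange in the sulfonamide series: cytotoxicity

The source may hold more compounds than are shown below. What is called first, only, known or untested is meant among the compounds shown, and "the series" means these compounds.

Measured compounds:
Compound 1 `COc1cccc(C(=O)NCCNC(=O)[C@H](CC(=O)NC(C)(C)C)NS(=O)(=O)c2ccc(C)cc2)c1`; in an ADME assay on Karpas-1106P cells (Homo sapiens) for cytotoxicity (on this read-out higher numbers stand for an effect only at larger amounts of compound and lower numbers for an effect already at smaller amounts), compound 1 gives only a limit, > 11100 nM.
Compound 2 `COc1cc(OC)cc(C(=O)NCCNC(=O)[C@H](CC(=O)NC(C)(C)C)NS(=O)(=O)c2ccc(C)cc2)c1`; in this assay compound 2 gives only a limit, > 11100 nM.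
Compound 3 `Cc1ccc(S(=O)(=O)N[C@@H](CC(=O)NC(C)(C)C)C(=O)NCCNC(=O)c2cc(Cl)ccc2Cl)cc1`; in this assay compound 3 gives only a limit, > 11100 nM.

Compound 1 thus stands at a limit of this assay, not at a number, and so do the other two; the shared position is the limit of > 11100 nM in this assay, at which 3 of the 3 values shown sit. The steps a step that the two limits leave unreadable from compound 1 to compound 2 and a step that the two limits leave unreadable from compound 1 to compound 3 are therefore of unreadable size. Compound 4 `Cc1ccc(S(=O)(=O)N[C@@H](CC(=O)NC(C)(C)C)C(=O)NCCNC(=O)c2ccccn2)cc1` differs from compound 1 by pyridin-2-yl in place of 3-methoxyphenyl on a carbonyl carbon. Both measured steps exchange the aryl group on the same carbonyl carbon, and neither gives a readable size, so no step beyond the scatter can be expected from them; the expected step is a number no higher from compound 1 to compound 4 (the limit leaves the size open). Compound 4 is expected, most likely again as a limit, at 11100 nM, with a range from 5000 nM to 30000 nM.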

Compound 4, half-maximal effective concentration: > 11100 nM
Compound 4 gave a limit, no number (the forecaster's own chance of this, stated with the estimate: 85%); the middle value sits exactly at the limit.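

Among these compounds, no step from compound 4 to compound 1, compound 2 or compound 3 can be read, since all four stand at one shared position: the limit of > 11100 nM in this assay, at which 4 of the 4 values shown sit. The compounds shown leave open where their true values lie and whether exchanging the aryl group on this carbonyl carbon changes the read-out at all.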